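The source may hold more compounds than are shown below. What is called first, only, known or untested is meant among the compounds shown, and "the series" means these compounds.

Going by the values given here, in a functional assay on cells for agonist activity at Free fatty acid receptor 1 (Homo sapiens), read by FLIPR and calcium flux, with a stated time of 100 s (on this read-out lower numbers stand for an effect already at smaller amounts and higher numbers for an effect only at larger amounts of compound), compound 1 `O=C(O)C[C@@H]1C[C@H](C(F)(F)F)CN1c1ccc(Oc2ccccc2C(F)(F)F)cc1` gives 310 nM, and compound 2 `O=C(O)C[C@@H]1C[C@H](C(F)(F)F)CN1c1ccc(Oc2ccccc2OC(F)(F)F)cc1` gives 170 nM; these are the only two numbers measured so far, and the step of a 1.8-fold lower number from compound 1 to compound 2 (0.26 log units; within the scatter) lies within the scatter. Compound 3 `COc1ccc(Oc2ccc(N3C[C@@H](C(F)(F)F)C[C@H]3CC(=O)O)cc2)c(C)c1` carries 4-methoxy-2-methylphenyl in place of 2-(trifluoromethyl)phenyl on an oxygen on an aromatic ring. Among the compounds with values here, the single measured step, from compound 1 to compound 2, exchanges one fluorinated group for another at the same place and so bears only loosely on a change that brings in a methoxy and a methyl. Compound 3 is therefore expected to show a 1.2-fold lower number from compound 1 to compound 3 (0.09 log units; within the scatter), nothing beyond the scatter, with an estimate of 250 nM and a range from 60 nM to 1000 nM.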

Compound 3, half-maximal effective concentration: 55 nM
Compound 3: middle estimate off by 4.5-fold (0.66 log units), on the high side; the whole stated range lies above it.
By their numbers in this assay, from the lowest: compound 3; then compounds 2 and 1 (each within the scatter of the next).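

In this assay, going by these compounds alone, the group on the oxygen on an aromatic ring can move the number beyond the scatter: 4-methoxy-2-methylphenyl in place of 2-(trifluoromethyl)phenyl gives the largest step so far (a 5.6-fold lower number from compound 1 to compound 3 (0.75 log units; beyond the scatter)). The earlier exchange of one fluorinated group for another stayed within the scatter, so a change at this place is not always as small as that one. Nothing available bears on why the number falls here.

Methoxy and methyl enter together, so the share of each in this step stays open. Also open, going by these compounds, is how an ethoxy or an amine in place of the methoxy would read in this assay.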